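Cytotoxicity at the limit: the nitro to methoxy step

The source may report more compounds than this note shows. Statements on the series, on what has been measured and on what is new or still open speak of the compounds shown alone.

Compound 1 `O=c1ccoc2cc(OCc3cn(Cc4ccc([N+](=O)[O-])cc4)nn3)ccc12` is read in an ADME assay on L02 cells (Homo sapiens) for cytotoxicity, read by MTT assay, with a stated time of 48 h (a higher number here means a weaker inhibitor, a lower number a stronger inhibitor), only as a limit of the assay: compound 1 gives > 300000 nM. Compound 2 `O=c1ccoc2cc(OCc3cn(Cc4ccccc4Cl)nn3)ccc12` sits at the same limit, and in this assay compound 2 gives > 300000 nM. Compound 3 `O=c1ccoc2cc(OCc3cn(Cc4ccccc4)nn3)ccc12` likewise gives > 300000 nM in this assay, a limit and not a number. The three steps between them, a step that the two limits leave unreadable from compound 1 to compound 2, a step that the two limits leave unreadable from compound 1 to compound 3 and a step that the two limits leave unreadable from compound 2 to compound 3, are therefore not readable in size; the whole set stands at the limit of > 300000 nM in this assay, at which 3 of the 3 values shown sit.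

Compound 4 `COc1ccc(Cn2cc(COc3ccc4c(=O)ccoc4c3)nn2)cc1` differs from compound 1 as follows: methoxy in place of nitro on an aromatic carbon. The closest measured step, a step that the two limits leave unreadable from compound 1 to compound 3, takes nitro away but puts hydrogen in its place, and both of its ends sit at the limit. Within the data shown here, no step in the set lifts any compound off the limit, so neither a size nor a direction can be read for the change at hand. Compound 4 is expected to stay at the limit as well, estimated at 300000 nM with a range of 150000 nM to 1000000 nM in this assay. As a step this means a number no higher from compound 1 to compound 4 (the limit leaves the size open) is expected, nothing beyond the scatter.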

Compound 4, half-maximal inhibitory concentration: > 300000 nM
Compound 4: no number, only a limit; the forecaster's own chance of this, stated with the estimate: 85%; the middle value sits exactly at the limit.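

Compound 4 joins compound 1, compound 2 and compound 3 at a limit and not a number, so none of its steps to them can be read: the limit of > 300000 nM in this assay, at which 4 of the 4 values shown sit. The compounds shown leave open whether any group on this aromatic ring gives a readable number in this assay.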